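A few compounds are considered here, and "the series" means these few. Any claim that something is new, unique, unknown or untested is made for them only; others in the source may bear on it.

Within the data shown here, compound 1 `CC(C)CSc1nc(N)nc2c1ncn2/C=C1/CC1(CO)CO` is the only member of this series with a numerical result in an ADME assay on CCRF-HSB-2 cells (Homo sapiens) for cytotoxicity, with a stated time of 7 days (a higher number here means that more compound is tolerated, a lower number that less compound is tolerated), where compound 1 gives 60000 nM. For compound 2 `CCCCCOc1nc(N)nc2c1ncn2/C=C1/CC1(CO)CO` the result in this assay is a limit, > 20000 nM. For compound 3 `Nc1nc(N2CCCC2)c2ncn(/C=C3/CC3(CO)CO)c2n1` the result in this assay is likewise a limit, > 20000 nM. Hence a step that the limit leaves unreadable from compound 1 to compound 2, a step that the limit leaves unreadable from compound 1 to compound 3 and a step that the two limits leave unreadable from compound 2 to compound 3, since (the limit of > 20000 nM in this assay, at which 2 of the 3 values shown sit). Compound 4 `CCCCCCCCSc1nc(N)nc2c1ncn2/C=C1/CC1(CO)CO` differs from compound 1 by heptyl in place of isopropyl on a saturated chain carbon bound to a sulfur. Among the measured compounds shown here, no measured step varies the chain at this position, so none bears directly on it; the expectation rests on compound 1 alone at 60000 nM, with a step of a 1.3-fold lower number from compound 1 to compound 4 (0.12 log units; within the scatter) expected, within the scatter. Compound 4 is therefore estimated at 45000 nM, in the range 12000 nM to 120000 nM.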

Compound 4, half-maximal cytotoxic concentration: 60000 nM
For compound 4 the middle estimate is 1.3-fold (0.12 log units) below the measured one; the measured number falls inside the stated range.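

The series now has one readable step in this assay: octylsulfanyl in place of isobutylsulfanyl gives no change at the digits printed from compound 1 to compound 4 (within the scatter). At this position, on a saturated chain carbon bound to a sulfur, this single pair therefore shows that heptyl in place of isopropyl leaves the read-out unshifted. The steps to compound 4 from compound 2 and from compound 3 cannot be read: the limit of > 20000 nM in this assay, at which 2 of the 4 values shown sit.

As far as these compounds go, a chain carrying an amine or a carboxylic acid at its end remains open at this position. So does a short methyl group in place of the isobutyl.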